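Swapping One Group on the Shared Core

The compounds below may be only part of what the source reports. "The series", "measured", "known", "first", "only" and "open" are said of these compounds alone.

Measured in an ADME assay on MDCK cells (Canis lupus familiaris) for permeability, read by LC-MS, with a stated time of 90 min, tested at 2 uM; a lower number here means that the compound crosses the layer more slowly, a higher number that the compound crosses the layer faster:
Compound 1 (`COc1cc(C)[nH]c(=O)c1CN1CCc2c(Cl)cc(-c3c(C)noc3C)c(Cl)c2C1=O`): 11 10^-6 cm/s
Compound 2 (`Cc1cc(C)c(CN2CCc3c(Cl)cc([C@H](CO)[C@H]4CCCO4)c(Cl)c3C2=O)c(=O)[nH]1`): 4.1 10^-6 cm/s

Going by the values given here, of these two numbers, the one for compound 2 is the lower at 4.1 10^-6 cm/s. Compound 1 stands higher, and the gap between the two lies beyond the scatter. The next compound to be tested in this assay is compound 3 (`Cc1cc(C)c(CN2CCc3c(Cl)cc(-c4c(C)noc4C)c(Cl)c3C2=O)c(=O)[nH]1`). It differs from compound 2 in one place: a group of 7 heavy atoms (5 carbon, 1 nitrogen, 1 oxygen; one five-membered aromatic ring with 2 hetero atoms) in place of a group of 8 heavy atoms (6 carbon, 2 oxygen; one five-membered non-aromatic ring with 1 hetero atom), on an aromatic carbon. The new group, 3,5-dimethyl-1,2-oxazol-4-yl, sits on an aromatic carbon.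

Among the compounds with values here, no measured pair of compounds differs in just one place, so the data give no direct guide to the size of this step. Within the data shown here, the only support is compound 1, which carries that same group and gives 11 10^-6 cm/s. On that basis, a rise beyond the scatter is expected, and the estimated step is a 2.4-fold higher number from compound 2 to compound 3 (0.39 log units; beyond the scatter). With so little evidence, the range is kept wide. The estimate for compound 3 is 10 10^-6 cm/s, with an expected range from 5 10^-6 cm/s to 20 10^-6 cm/s.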

Compound 3, apparent permeability: 15.7 10^-6 cm/s
The estimate for compound 3 lay 1.6-fold (0.20 log units) below the measured number; the range from low to high includes it.
By their numbers in this assay, from the lowest: compound 2; then compounds 1 and 3 (each within the scatter of the next).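

In this assay, this position now has its first comparison in which nothing else changes: 3,5-dimethyl-1,2-oxazol-4-yl, in place of the group with the five-membered non-aromatic ring, gives a 3.8-fold higher number from compound 2 to compound 3 (0.58 log units; beyond the scatter). Compound 1 and compound 2 differ in more than one place, so their gap could not be assigned to this position, whereas this step shows a change beyond the scatter from the swap on this aromatic carbon alone. The other single change, methyl in place of methoxy on an aromatic carbon, gives a 1.4-fold higher number from compound 1 to compound 3 (0.15 log units; within the scatter), and the compounds shown offer no sign that this swap moves the number, while nothing here gives a reason for either step.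

From the compounds shown here alone, the position rests on just two groups, so it remains open whether a plain phenyl ring, a morpholine or a primary amine on this aromatic carbon would stay near compound 3 or fall nearer compound 2. The leaving group also has two defined stereocentres, and the compounds shown leave open how its other stereoisomers would compare.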